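Sulfonyl in Place of Carbonyl on the Anilide Nitrogen

A few compounds are considered here, and "the series" means these few. Any claim that something is new, unique, unknown or untested is made for them only; others in the source may bear on it.

Compound 1 `O=C(Nc1cccc(/C=C/C(=O)c2nc3ccccc3[nH]2)c1)c1ccc(Cl)cc1` gives 2270 nM in a functional assay on HCT-116 cells (Homo sapiens) for antiproliferative activity, read by MTT assay, with a stated time of 48 h; on this read-out lower numbers stand for stronger inhibition and higher numbers for weaker inhibition. Among the three measured compounds it stands second highest: compound 2 `Cc1cccc(C(=O)Nc2cccc(/C=C/C(=O)c3nc4ccccc4[nH]3)c2)c1` gives 1420 nM, a step of a 1.6-fold lower number from compound 1 to compound 2 (0.20 log units; within the scatter) that lies within the scatter, while compound 3 `COc1ccc(C(=O)Nc2cccc(/C=C/C(=O)c3nc4ccccc4[nH]3)c2)cc1` gives 4880 nM, a step of a 2.1-fold higher number from compound 1 to compound 3 (0.33 log units; beyond the scatter) that goes beyond it. Compound 2 and compound 3 are separated by a 3.4-fold higher number from compound 2 to compound 3 (0.54 log units; beyond the scatter).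

Compound 4 `O=C(/C=C/c1cccc(NS(=O)(=O)c2cccc(Cl)c2)c1)c1nc2ccccc2[nH]1` differs from compound 1 in one place: (3-chlorophenyl)sulfonyl in place of (4-chlorophenyl)carbonyl on a nitrogen on an aromatic ring. Within the data shown here, none of the three measured steps bears on this change directly, since each of them exchanges one aryl group for another on a carbonyl carbon and leaves the carbonyl in place; together they show only that changes at this end of the molecule have produced modest steps in either direction. Among the measured compounds shown here, with no closer precedent, compound 4 is expected to land near compound 1, with a wide margin for the untested exchange of carbonyl for sulfonyl: the estimate for compound 4 is 2500 nM, between 800 nM and 8000 nM. This expected step is a 1.1-fold higher number from compound 1 to compound 4 (0.04 log units; within the scatter).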

Compound 4, half-maximal inhibitory concentration: 737 nM
Beside the measured number, compound 4's estimate is 3.4-fold (0.53 log units) above it; the measured number lies below the stated range.
By their numbers in this assay, from the lowest: compounds 4, 2 and 1 (each within the scatter of the next, the first and the last beyond it); then compound 3.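

The anilide nitrogen carries a sulfonyl as well as a carbonyl: in this assay the exchange of (4-chlorophenyl)carbonyl for (3-chlorophenyl)sulfonyl gives a 3.1-fold lower number from compound 1 to compound 4 (0.49 log units; beyond the scatter) and so brings a step at this position that is beyond the scatter. The other two steps are a 6.6-fold lower number from compound 3 to compound 4 (0.82 log units; beyond the scatter) and a 1.9-fold lower number from compound 2 to compound 4 (0.28 log units; within the scatter) and show that the sulfonyl compound stands clear of two of the carbonyl compounds but not of the third. Nothing measured here accounts for these steps.

The exchange joins two changes, carbonyl to sulfonyl and 4-chloro to 3-chloro on the phenyl, and the compounds shown do not part them. Also open, as far as these compounds go, is how the sulfonyl series responds to a methoxy group or an amine on that phenyl, or to methylsulfonyl in its place.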